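This account rests on a few compounds, and the source may have more. Where it says the series, first, only, none or still open, it means among the compounds named here.

Three compounds of a shared core have so far been run in an ADME assay (Canis lupus familiaris, strain Beagle) for pharmacokinetics; on this read-out lower numbers stand for narrower distribution and higher numbers for wider distribution into tissues. Compound 1 `CCn1c(-c2ccc(C(F)(F)F)nc2)nc2c(O[C@H]3CCN(C(=O)N4CC(OC)C4)C3)ncnc21` gives 0.7 L/kg, compound 2 `CCn1c(-c2cnc(C)nc2)nc2c(O[C@H]3CCN(C(=O)C4CCC4)C3)ncnc21` gives 1 L/kg, and compound 3 `CCC(=O)N1CC[C@H](Nc2ncnc3c2nc(-c2cnc(C)nc2)n3CC)C1` gives 1.5 L/kg. On these three numbers compound 2 sits in the middle: the nearest value to it is that of compound 1, the furthest that of compound 3, and both gaps fall within the usual scatter of repeated measurements in this assay, so nothing separates the three compounds beyond noise.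

Compound 4 `CCn1c(-c2cnc(C)nc2)nc2c(O[C@H]3CCN(C(=O)[C@H]4C[C@@H](OC)C4)C3)ncnc21` has not yet been measured in this assay. It is built from compound 2 by one change, (methoxy in place of hydrogen on a saturated ring carbon); cut one bond further out, the change reads cyclobutylcarbonyl to (3-methoxycyclobutyl)carbonyl. Within the data shown here, no pair of measured compounds shows the same alteration, so there is no directly comparable step to lean on. Given that the three measured compounds, despite differing in several places, all sit within the scatter of one another, the step of no change at the digits printed from compound 2 to compound 4 (within the scatter) is expected to be small, with no direction beyond the scatter.

Accordingly, compound 4 is estimated to give 1 L/kg in this assay, within a range of 0.6 L/kg to 1.7 L/kg.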

Compound 4, volume of distribution: 0.6 L/kg
Compound 4: the middle estimate sits 1.7-fold (0.22 log units) above what was measured, and the stated range covers the measured number.
By their numbers in this assay, from the lowest: compounds 4, 1, 2 and 3 (each within the scatter of the next, the first and the last beyond it).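

In this assay, the series now has its first step that changes one place only, a 1.7-fold lower number from compound 2 to compound 4 (0.22 log units; within the scatter), and it shows that methoxy in place of hydrogen on a saturated ring carbon of this four-membered ring leaves the read-out within the scatter. The earlier compounds shown here differed in several places at once, so they could say nothing about this ring on its own; this step shows that cyclobutylcarbonyl can become (3-methoxycyclobutyl)carbonyl without a change that can be told from noise. No measurement shown here offers an explanation for the step.

Going by these compounds, it remains open whether another group on this ring carbon, such as an amine, a carboxylic acid or a longer chain like butoxy, would move the read-out beyond the scatter, and whether the methoxy group would give the same result in the other spatial arrangement on the ring. A single step also leaves open whether this change would behave alike in compounds carrying the trifluoromethyl-bearing aromatic ring of compound 1.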